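The source may hold more compounds than are shown below. What is called first, only, known or untested is meant among the compounds shown, and "the series" means these compounds.

Measured compounds in a functional assay on NCI-H1299 cells (Homo sapiens) for inhibition, read by CCK-8 assay, with a stated time of 72 h, tested at 1 uM; a lower number here means a weaker effect, a higher number a stronger effect of the compound at the concentration tested:
- compound 1 `CN(C)C(=O)c1cc2cnc(Nc3ccc(C(=O)NCCCCCN=C=S)cc3)nc2n1C1CCCC1` gives 50.3%
- compound 2 `CN(C)C(=O)c1cc2cnc(Nc3ccc(C(=O)NCCCCCN=C=S)cc3F)nc2n1C1CCCC1` gives 36.1%
- compound 3 `CN(C)C(=O)c1cc2cnc(Nc3ccc(C(=O)NCCCCN=C=S)cc3O)nc2n1C1CCCC1` gives 10.7%

Compound 3 stands lowest of the three in this assay , separated from both others by more than the usual scatter. Compound 4 `CN(C)C(=O)c1cc2cnc(Nc3ccc(C(=O)NCCCCCN=C=S)cc3O)nc2n1C1CCCC1` has not yet been tested. It differs from compound 3 in one place: a group of 4 heavy atoms (2 carbon, 1 nitrogen, 1 sulfur; no ring) in place of a group of 3 heavy atoms (1 carbon, 1 nitrogen, 1 sulfur; no ring), on a saturated chain carbon, four bonds along the chain from an amide-type nitrogen. This change lengthens the saturated chain that carries the isothiocyanate, without touching the rest of the molecule.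

Among the compounds with values here, only one measured step exists, a number 14.2 percentage points lower from compound 1 to compound 2 (beyond the scatter), and it concerns the aromatic ring, not the chain. Within the data shown here, no measured pair shows what a longer chain does on its own, so no direct guidance is available. Compound 3 itself is the weakest measured compound, and compound 4 shares its hydroxy-bearing ring while carrying the chain length of compound 1 and compound 2. Compound 4 is therefore expected to remain weak, with a step of a number 9.3 percentage points higher from compound 3 to compound 4 (within the scatter). The estimate for compound 4 is 20%, within a range from 5% to 40%.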

Compound 4, a percentage reported as inhibition, at one concentration (the size of the read-out at that concentration, not a potency): 22.6%
Estimate against measurement, compound 4: 2.6 percentage points below; measured number inside the range.
By their numbers in this assay, from the lowest: compound 3; then compound 4; then compound 2; then compound 1.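

Within the data shown here, with the hydroxy-bearing ring held fixed in this assay, lengthening the saturated chain that carries the isothiocyanate gives a number 11.9 percentage points higher from compound 3 to compound 4 (beyond the scatter), so chain length alone moves this read-out, which no earlier pair could show. At the longer chain length, the group on the aromatic carbon can also be compared more fully: hydroxy in place of fluoro gives a number 13.5 percentage points lower from compound 2 to compound 4 (beyond the scatter), and hydroxy in place of hydrogen gives a number 27.7 percentage points lower from compound 1 to compound 4 (beyond the scatter), so among these three groups, hydroxy goes with the lowest number. Nothing shown here explains either change.

As far as these compounds go, it remains open whether lengthening the chain has the same effect with hydrogen or fluoro on the aromatic carbon. From the compounds shown here alone, what a still longer chain, or a methoxy group in place of the hydroxy, would do also remains open.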